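The compounds below may be only part of what the source reports. "The series", "measured", "known", "first", "only" and "open" are said of these compounds alone.

Compound 1, `O=C(Nc1cccc(-n2cc(-c3ccncc3)c(-c3ccc(Cl)c(O)c3)n2)c1)Nc1cccc(C(F)(F)F)c1`, gives 1900 nM in a functional assay on NCI-H23 cells (Homo sapiens) for inhibition, read by sulforhodamine B assay, with a stated time of 48 h; on this read-out lower numbers stand for stronger inhibition of growth and higher numbers for weaker inhibition of growth. Compound 2, `COc1cc(-c2nn(-c3cccc(NC(=O)Nc4cc(C(F)(F)F)cc(C(F)(F)F)c4)c3)cc2-c2ccncc2)ccc1Cl`, gives 1090 nM. Compound 3, `COc1cc(-c2nn(-c3cccc(NC(=O)Nc4cccc(C(F)(F)F)c4)c3)cc2-c2ccncc2)ccc1Cl`, gives 1180 nM.

Compound 2 holds the lowest of the three numbers, but only within the scatter: a 1.1-fold higher number from compound 2 to compound 3 (0.03 log units; within the scatter), and compound 1 stands a little further off, also within the scatter.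

Compound 4, `O=C(Nc1cccc(-n2cc(-c3ccncc3)c(-c3ccc(Cl)c(O)c3)n2)c1)Nc1cc(C(F)(F)F)cc(C(F)(F)F)c1`, is compound 2 with hydrogen in place of methyl on an oxygen on an aromatic ring. For the measured compounds named here, one measured step bears directly on this change, in the opposite direction: a 1.6-fold lower number from compound 1 to compound 3 (0.21 log units; within the scatter). Run backwards, it points to a somewhat higher number for compound 4 in this assay, but nothing beyond the scatter is expected. Compound 4 is therefore estimated at 1700 nM, with a range from 800 nM to 3600 nM. The expected step is a 1.6-fold higher number from compound 2 to compound 4 (0.19 log units; within the scatter).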

Compound 4, concentration for 50% growth inhibition: 1020 nM
Compound 4: middle estimate off by 1.7-fold (0.22 log units), on the high side; low and high end bracket the measured number.
By their numbers in this assay, from the lowest: compounds 4, 2, 3 and 1 (each within the scatter of the next).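

In this assay, the change from methoxy to hydroxy now has a second reading, a 1.1-fold lower number from compound 2 to compound 4 (0.03 log units; within the scatter), and on both cores it stays within the scatter: the same change on two cores in this assay, a 1.6-fold lower number (0.21 log units; within the scatter) from compound 1 to compound 3 and a 1.1-fold higher number (0.03 log units; within the scatter) from compound 4 to compound 2, 1.7-fold (0.24 log units) apart, within the scatter of two such steps. Trifluoromethyl in place of hydrogen on an aromatic carbon also has a second reading, a 1.9-fold lower number from compound 1 to compound 4 (0.27 log units; within the scatter), and it too stays within the scatter: the same change on two cores in this assay, a 1.1-fold higher number (0.03 log units; within the scatter) from compound 2 to compound 3 and a 1.9-fold higher number (0.27 log units; within the scatter) from compound 4 to compound 1, 1.7-fold (0.24 log units) apart, within the scatter of two such steps. Neither change moves the number beyond the scatter among these four compounds.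

Going by these compounds, whether a longer chain on this oxygen, or an amine or a carboxylic acid in place of the methoxy, would move the number beyond the scatter stays open.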